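The source may hold more compounds than are shown below. What is called first, only, known or untested is meant among the compounds shown, and "the series" means these compounds.

Measured compounds:
compound 1, `COC1(c2csc(Sc3ccc4c(c3)CC/C4=N\OCC#N)c2)CCOCC1`, 40 nM
compound 2, `C/C(=N\OCCSc1nnnn1C)c1ccc(Sc2cc(F)cc(C3CCOCC3)c2)cc1`, 120 nM

The two measured compounds share no single-point relation, so only their values can be compared. In a functional assay (blood) for inhibition, with Homo sapiens as the target (a lower number here means a stronger inhibitor, a higher number a weaker inhibitor), compound 2 gives the higher of the two numbers; compound 1 gives the lower, and the gap between them lies beyond the scatter.

Compound 3, `C/C(=N\OCCSc1nnc(C)s1)c1ccc(Sc2cc(F)cc(C3CCOCC3)c2)cc1`, has not yet been measured in this assay. It differs from compound 2 in one place: 5-methyl-1,3,4-thiadiazol-2-yl in place of 1-methyl-1H-tetrazol-5-yl on a sulfur. Among the compounds with values here, both groups are five-membered aromatic rings of the same heavy-atom count, so no step between measured compounds here tells how such a swap plays out, and the expectation can rest only on compound 2 and its value 120 nM.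

The expected step from compound 2 to compound 3, no change at the digits printed from compound 2 to compound 3 (within the scatter), is none beyond the scatter. Compound 3 is estimated at 120 nM, with a range from 50 nM to 300 nM.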

Compound 3, half-maximal inhibitory concentration: 230 nM
Compound 3: middle estimate off by 1.9-fold (0.28 log units), on the low side; the measured number falls inside the stated range.
By their numbers in this assay, from the lowest: compound 1; then compounds 2 and 3 (each within the scatter of the next).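

In this assay, within the data shown here, the first step at this position, a 1.9-fold higher number from compound 2 to compound 3 (0.28 log units; within the scatter), stays within the scatter. The position on a sulfur, at the end of the 2-sulfanylethyl chain, therefore accepts 5-methyl-1,3,4-thiadiazol-2-yl in place of 1-methyl-1H-tetrazol-5-yl with no change that can be read, even though the ring swaps nitrogen for carbon and sulfur and goes from 4 hydrogen-bond acceptors to 3. Nothing at hand bears on why these two rings read alike.

Still open, going by these compounds, is whether a group other than an aromatic ring, such as an amine or a carboxylic acid, or a longer chain in place of the ethyl, would keep the number in this range. Also open, on these data alone, is whether the same ring swap would read alike on the core of compound 1.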